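Moving the isopropylpyrazole attachment point: working notes

The compounds below may be only part of what the source reports. "The series", "measured", "known", "first", "only" and "open" are said of these compounds alone.

Compound 1 `CCNC(=O)c1noc(-c2cc(C(C)C)c(O)cc2O)c1-c1cc(C(=O)NC)no1`: 124 nM
Compound 2 `CCNC(=O)c1noc(-c2cc(C(C)C)c(O)cc2O)c1-c1ccn(C(C)C)n1`: 19 nM

Going by the values given here, in a functional assay on HCT-116 cells (Homo sapiens) for inhibition (a lower number here means a stronger inhibitor, a higher number a weaker inhibitor), compound 2 gives 19 nM as the lower of the two numbers so far. Compound 3 `CCNC(=O)c1noc(-c2cc(C(C)C)c(O)cc2O)c1-c1cnn(C(C)C)c1` differs from it as follows: 1-isopropyl-1H-pyrazol-4-yl in place of 1-isopropyl-1H-pyrazol-3-yl on an aromatic carbon. Among the compounds with values here, the one measured step at this place, a 6.5-fold lower number from compound 1 to compound 2 (0.81 log units; beyond the scatter), exchanged a different group, so it sets no size for moving the attachment point. Within the data shown here, no measured step shows a direction for this change either. Only a small change is therefore expected, with a 1.3-fold higher number from compound 2 to compound 3 (0.12 log units; within the scatter) as the estimated step. For compound 3 the estimated value is 25 nM with an expected range from 8 nM to 80 nM.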

Compound 3, half-maximal inhibitory concentration: 21 nM
Compound 3: the middle estimate sits 1.2-fold (0.08 log units) above what was measured, within the range that was stated.
By their numbers in this assay, from the lowest: compounds 2 and 3 (each within the scatter of the next); then compound 1.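

In this assay, moving the attachment point gives a 1.1-fold higher number from compound 2 to compound 3 (0.04 log units; within the scatter), so 1-isopropyl-1H-pyrazol-3-yl and 1-isopropyl-1H-pyrazol-4-yl cannot be told apart at this position. The advantage over 3-(methylcarbamoyl)-1,2-oxazol-5-yl holds for the second attachment point too, with a 5.9-fold lower number from compound 1 to compound 3 (0.77 log units; beyond the scatter).

Still open, on these data alone, is whether the isopropyl on the pyrazole is needed, or whether methyl, cyclopropyl or a longer chain ending in an amine would serve equally well. No measurement is at hand that accounts for this result.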